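Hydroxy to trifluoromethyl on the aryl urea of compound 3

This account rests on a few compounds, and the source may have more. Where it says the series, first, only, none or still open, it means among the compounds named here.

Compound 1 `COc1cc(NC(C)CCCNC(=O)NNC(=O)Nc2ccc(Br)cc2)c2ncccc2c1` gives 100 nM in a functional assay on MCF7 cells (Homo sapiens) for inhibition, read by MTT assay, with a stated time of 72 h; on this read-out lower numbers stand for stronger inhibition and higher numbers for weaker inhibition. Compound 2 `COc1cc(NC(C)CCCNC(=O)NNC(=O)Nc2cccc(Cl)c2)c2ncccc2c1` gives 220 nM in this assay, a step of a 2.2-fold higher number from compound 1 to compound 2 (0.34 log units; beyond the scatter). Compound 3 `COc1cc(NC(C)CCCNC(=O)Nc2cccc(O)c2)c2ncccc2c1` gives 11000 nM in this assay and stands highest of the three numbers; the steps of a 110-fold higher number from compound 1 to compound 3 (2.04 log units; beyond the scatter) and a 50-fold higher number from compound 2 to compound 3 (1.70 log units; beyond the scatter) are both large and both beyond the scatter. Compound 4 `COc1cc(NC(C)CCCNC(=O)Nc2cccc(C(F)(F)F)c2)c2ncccc2c1` is not yet measured in this assay. It differs from compound 3 by trifluoromethyl in place of hydroxy on an aromatic carbon. Among the compounds with values here, no measured step exchanges one substituent for another on the six-membered aromatic ring of carbon only while keeping the rest of the molecule fixed in the way this change does: the step from compound 1 to compound 2 swaps one halogen-bearing aryl for another and is modest, whereas the large steps into compound 3 remove the whole ((4-bromophenyl)carbamoyl)amino or ((3-chlorophenyl)carbamoyl)amino unit and say nothing about the hydroxy itself. The expectation for compound 4 in this assay therefore rests on thin ground: a step of a 2.2-fold lower number from compound 3 to compound 4 (0.34 log units; beyond the scatter) toward a lower number is expected, with wide uncertainty. Compound 4 is estimated at 5000 nM in this assay, with a range from 1000 nM to 25000 nM.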

Compound 4, half-maximal inhibitory concentration: 3300 nM
Estimate against measurement, compound 4: 1.5-fold (0.18 log units) above; the range from low to high includes it.
By their numbers in this assay, from the lowest: compound 1; then compound 2; then compound 4; then compound 3.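

In this assay, trifluoromethyl in place of hydroxy gives a 3.3-fold lower number from compound 3 to compound 4 (0.52 log units; beyond the scatter) and is the only step shown that exchanges one substituent on this aromatic ring while the rest of the molecule stays fixed, so this position does respond to the substituent it carries, though only modestly. The large gap to the compounds with the longer carbamoylamino unit remains after the exchange, at a 15-fold higher number from compound 2 to compound 4 (1.18 log units; beyond the scatter) and a 33-fold higher number from compound 1 to compound 4 (1.52 log units; beyond the scatter) in the same assay, so the weak numbers of compound 3 are not tied to the hydroxy alone, and the substituent step is smaller than either of these steps. No measurement bearing on the reason for either size of step is available.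

As far as these compounds go, whether the lower number follows from removing the hydroxy or from adding trifluoromethyl stays open, and an unsubstituted phenyl, an amine, a carboxylic acid or a methoxy at this place would help separate the two. Also open, from the compounds shown here alone, is whether the same exchange moves the number in the same direction on the aryl of the longer chain in compound 2.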